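Thienopyrimidine amide to ester: an unmeasured step

This account rests on a few compounds, and the source may have more. Where it says the series, first, only, none or still open, it means among the compounds named here.

Compound 1 `COc1cccc(-c2nc(SC)nc3sc(C(=O)NCC#N)c(N)c23)c1` — in a functional assay on HEK293 cells for agonist activity at lutropin-choriogonadotropic hormone receptor (Homo sapiens), read by cAMP accumulation (a lower number here means that less compound is needed, a higher number that more compound is needed for the effect), compound 1 gives "not determined" (no result reported).
Compound 2 `COc1cccc(-c2nc(SC)nc3sc(C(=O)NC(C)(C)C)c(N)c23)c1F` — in this assay compound 2 gives 1500 nM.

Compound 1 has no number in this assay, so it stands nowhere on the scale; only compound 2 gives a reference point. Compound 3 `COc1cccc(-c2nc(SC)nc3sc(C(=O)OC(C)(C)C)c(N)c23)c1` differs from compound 1 by tert-butoxy in place of (cyanomethyl)amino on a carbonyl carbon. Within the data shown here, no measured pair shows this change, so its size and direction are unknown; a step beyond the scatter in either direction is plausible, as is none. Compound 3 is expected to give about 600 nM in this assay, within 60 nM to 6000 nM.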

Compound 3, half-maximal effective concentration: 1100 nM
Compound 3: middle estimate off by 1.8-fold (0.26 log units), on the low side; the range from low to high includes it.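

In this assay, among these compounds, compound 1 has no number, so no step from compound 1 to compound 3 can be read. From the compounds shown here alone, the size and direction of the change from (cyanomethyl)amino to tert-butoxy remain open. No evidence bears on this result.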